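From methoxy to hydroxy on compound 1

The source may hold more compounds than are shown below. What is called first, only, known or untested is meant among the compounds shown, and "the series" means these compounds.

In a functional assay on MCF7 cells (Homo sapiens) for cytotoxicity, read by colorimetric assay (on this read-out higher numbers stand for weaker inhibition and lower numbers for stronger inhibition), compound 1 (`COc1cc([C@@H]2CCc3cc(O)c(OC)cc3O2)ccc1O`) gives 90100 nM and compound 2 (`COc1ccc2c(c1)O[C@H](c1ccc(O)c(OC)c1)CC2`) gives 88400 nM on the same read-out, so the two stand level within the scatter. Compound 3 (`COc1cc2c(cc1O)CC[C@@H](c1ccc(O)c(O)c1)O2`) is still unmeasured and carries hydrogen in place of methyl on an oxygen on an aromatic ring. Among the compounds with values here, the only measured step, a different change of hydrogen in place of hydroxy on an aromatic carbon, gave a 1.0-fold lower number from compound 1 to compound 2 (0.01 log units; within the scatter) and offers no sign of a shift. Nothing beyond the scatter is expected in this assay and the estimated step is a 1.2-fold lower number from compound 1 to compound 3 (0.08 log units; within the scatter) in either reading. For compound 3 the expected value is 75000 nM with an estimated range of 32000 nM to 170000 nM in this test.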

Compound 3, half-maximal inhibitory concentration: 110000 nM
For compound 3 the middle estimate is 1.5-fold (0.17 log units) below the measured one, within the range that was stated.
By their numbers in this assay, from the lowest: compounds 2, 1 and 3 (each within the scatter of the next).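

In this assay, hydrogen in place of methyl on an oxygen on an aromatic ring gives a 1.2-fold higher number from compound 1 to compound 3 (0.09 log units; within the scatter) and so turns the methoxy of compound 1 into a hydroxy without a shift beyond the scatter. The earlier step concerned only a hydroxy giving way to hydrogen on an aromatic carbon, whereas this one shows that the methyl on this oxygen can go with the read-out staying level. No evidence at hand gives a reason for this result.

Still open, going by these compounds, is whether an ethoxy group on this oxygen, or an amine in place of the hydroxy, would move the number beyond the scatter.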